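Pyrazole carboxamide series: MRC5 inhibition notes

The compounds below may be only part of what the source reports. "The series", "measured", "known", "first", "only" and "open" are said of these compounds alone.

Measured so far:
- compound 1 `CO[C@H]1CC[C@H](NC(=O)c2n[nH]cc2NC(=O)c2ccccc2C(F)(F)F)CC1`: 3300 nM
- compound 2 `COc1cccc(OC)c1C(=O)Nc1c[nH]nc1C(=O)NC1CC1`: > 50000 nM
- compound 3 `CO[C@H]1CC[C@H](NC(=O)c2n[nH]cc2NC(=O)c2cc3ccccn3n2)CC1`: 1000 nM

In an ADME assay on MRC5 cells (Homo sapiens) for inhibition, with a stated time of 72 h (on this read-out lower numbers stand for an effect already at smaller amounts and higher numbers for an effect only at larger amounts of compound), compound 1 gives 3300 nM and compound 3 gives 1000 nM. For compound 2 only a limit is reported, > 50000 nM, so that compound 2 stands at the limit of the limit of > 50000 nM in this assay, at which 1 of the 3 values shown sits, rather than at a number. Among the measured compounds shown here, no pair among the measured compounds differs in one place, so no measured step is available.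

Compound 4 `COc1cccc(OC)c1C(=O)Nc1c[nH]nc1C(=O)NCCN1CCCC1` differs from compound 2 by 2-(pyrrolidin-1-yl)ethyl in place of cyclopropyl on an amide-type nitrogen. Without a measured step for this change, the expectation for compound 4 rests on compound 2 alone: the step of an at least 1.6-fold lower number from compound 2 to compound 4 (0.22 log units; that floor lies within the scatter) is expected to stay within scatter or to move modestly toward an effect at smaller amounts. Compound 4 is estimated at 30000 nM, in the range 8000 nM to 50000 nM.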

Compound 4, half-maximal effective concentration: > 50000 nM
Compound 4 ended at the assay's limit; the forecaster's own chance of this, stated with the estimate: 55%; at least 1.6-fold (0.22 log units) between middle value and limit.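

Compound 2 and compound 4 both end at a limit rather than a number, so no step between them can be read: the limit of > 50000 nM in this assay, at which 2 of the 4 values shown sit.

On these data alone, whether 2-(pyrrolidin-1-yl)ethyl in place of cyclopropyl changes the read-out at all remains open.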